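The source may report more compounds than this note shows. Statements on the series, on what has been measured and on what is new or still open speak of the compounds shown alone.

Compound 1 `Nc1ncnc2c1ncn2[C@@H]1S[C@H](CO)[C@H]1CO`: > 100000 nM, a limit
Compound 2 `OC[C@H]1[C@H](n2cnc3c(O)ncnc32)S[C@@H]1CO`: > 100000 nM, a limit
Compound 3 `Nc1ncnc2c1ncn2[C@H]1S[C@@H](CO)[C@@H]1CO`: > 100000 nM, a limit

All three entries from a functional assay on PBMC cells (Homo sapiens) for cytotoxicity (on this read-out lower numbers stand for stronger inhibition and higher numbers for weaker inhibition), are limits of the assay, not numbers. Compound 3 stands at the limit of > 100000 nM in this assay, at which 3 of the 3 values shown sit. Compound 4 `OC[C@H]1[C@H](CO)S[C@@H]1n1cnc2c(O)ncnc21` differs from compound 3 in one place: hydroxy in place of amino on an aromatic carbon. The same exchange gave a step that the two limits leave unreadable from compound 1 to compound 2. Inverting every stereocentre gave a step that the two limits leave unreadable from compound 1 to compound 3, and the fact that compounds 1 and 3 differ only in the configuration as drawn defines that pair. Neither step has a readable size. Compound 2, which carries hydroxy in place of amino, gives > 100000 nM, again a limit. On that evidence, no step beyond the scatter is expected in this assay, and the estimated change is a number no higher from compound 3 to compound 4 (the limit leaves the size open). Compound 4 is expected at 100000 nM, with an estimated range of 50000 nM to 200000 nM.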

Compound 4, half-maximal inhibitory concentration: > 100000 nM
Compound 4: only a limit was reported; the forecaster's own chance of this, stated with the estimate: 90%; the middle value lies on the limit itself.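

Compound 4 is also a limit, so neither the step to it from compound 3 nor the step to it from compound 2 can be read in this assay. The compounds shown leave open whether hydroxy in place of amino, or inverting every stereocentre, changes this read-out at all.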